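A few compounds are considered here, and "the series" means these few. Any claim that something is new, unique, unknown or untested is made for them only; others in the source may bear on it.

Measured in a functional assay on A-431 cells (Homo sapiens) for antiproliferative activity, read by MTT assay, with a stated time of 72 h; on this read-out higher numbers stand for weaker inhibition and lower numbers for stronger inhibition:
Compound 1 `CN1CCN(Cc2ccc(NC(=O)Nc3ccc4ncnc(Nc5cccc(C(=O)N6CCCC6)c5)c4c3)cc2)CC1`: > 10000 nM
Compound 2 `O=C(Nc1ccc(CN2CCCC2)cc1)Nc1ccc2ncnc(Nc3cccc(C(F)(F)F)c3)c2c1`: 1360 nM

The entry for compound 1 is a limit of the assay, not a number. Going by the values given here, compound 2, at 1360 nM, gives the only actual number so far. Compound 3 `COc1ccc(NC(=O)Nc2ccc3ncnc(Nc4cccc(C(F)(F)F)c4)c3c2)cc1` differs from compound 2 in one place: methoxy in place of (pyrrolidin-1-yl)methyl on an aromatic carbon. Methoxy stands in place of (pyrrolidin-1-yl)methyl on an aromatic carbon. Among the compounds with values here, no measured step gauges this change, so only a modest shift toward weaker inhibition in this assay is expected. The estimated change is a 1.8-fold higher number from compound 2 to compound 3 (0.26 log units; within the scatter). For compound 3 the estimated value is 2500 nM, with an expected range of 600 nM to 9000 nM.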

Compound 3, half-maximal inhibitory concentration: 4950 nM
Beside the measured number, compound 3's estimate is 2.0-fold (0.30 log units) below it; measured number inside the range.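

In this assay, replacing (pyrrolidin-1-yl)methyl with methoxy, on an aromatic carbon para to a large group, gives a 3.6-fold higher number from compound 2 to compound 3 (0.56 log units; beyond the scatter). This first measured step at this position shows that the group placed there can shift the read-out toward weaker inhibition. The only limit among the values belongs to compound 1, so this step can be read as a true number: the limit of > 10000 nM in this assay, at which 1 of the 3 values shown sits.

The compounds shown leave open whether the nitrogen, the ring or the count of heavy atoms accounts for the step. A dimethylaminomethyl group or a simple methyl group at this position could help separate these.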